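Urea nitrogen substituent in the piperazine dithiocarbamate series

The source may report more compounds than this note shows. Statements on the series, on what has been measured and on what is new or still open speak of the compounds shown alone.

Compound 1 `CCNC(=O)N1CCN(C(=S)SCc2cn(Cc3ccccc3F)nn2)CC1` and compound 2 `CC(C)(C)NC(=O)N1CCN(C(=S)SCc2cn(Cc3ccccc3F)nn2)CC1` share a core and differ only at the urea nitrogen. Within the data shown here, in a functional assay on MGC-803 cells (Homo sapiens) for cytotoxicity, read by MTT assay, with a stated time of 72 h (on this read-out higher numbers stand for weaker inhibition and lower numbers for stronger inhibition), compound 1 gives 2830 nM and compound 2 gives 40700 nM; compound 2 stands as the higher of the two numbers, and the step of a 14-fold higher number from compound 1 to compound 2 (1.16 log units; beyond the scatter) is the only measured step. Compound 3 `O=C(NC1CCCCC1)N1CCN(C(=S)SCc2cn(Cc3ccccc3F)nn2)CC1` continues from compound 2 with cyclohexyl in place of tert-butyl on an amide-type nitrogen. Among the measured compounds shown here, the one measured step bears on it only loosely: it shows that growing the substituent from ethyl to tert-butyl moved the number up strongly, but cyclohexyl is a ring rather than a branched chain, and no measured pair reports that change. The step of a 1.6-fold lower number from compound 2 to compound 3 (0.21 log units; within the scatter) is therefore expected to be small, with no confident direction. Compound 3 is estimated at 25000 nM, within the range 5000 nM to 100000 nM.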

Compound 3, half-maximal inhibitory concentration: 36500 nM
Beside the measured number, compound 3's estimate is 1.5-fold (0.16 log units) below it; measured number inside the range.
By their numbers in this assay, from the lowest: compound 1; then compounds 3 and 2 (each within the scatter of the next).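

In this assay the step of a 1.1-fold lower number from compound 2 to compound 3 (0.05 log units; within the scatter) places cyclohexyl and tert-butyl level on the amide-type nitrogen, so a six-membered carbon ring and a branched chain read alike at this position. The step of a 13-fold higher number from compound 1 to compound 3 (1.11 log units; beyond the scatter) shows that the large gap from ethyl is not particular to tert-butyl, since it appears with cyclohexyl as well and in a similar size. No evidence accompanies these numbers to say what lies behind them. 

Going by these compounds, whether methyl, shorter than ethyl, gives a lower number than ethyl stays open. Also open, on these data alone, is whether a longer straight chain such as n-butyl, or an ethyl chain carrying a hydroxyl group, reads with ethyl or with tert-butyl and cyclohexyl.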